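This account rests on a few compounds, and the source may have more. Where it says the series, first, only, none or still open, it means among the compounds named here.

Three compounds sharing one core and differing only in the aryl group on the amine nitrogen have been measured in an assay on isolated protein for inhibition of Dihydrofolate reductase (Homo sapiens), read by spectrophotometry; on this read-out higher numbers stand for weaker inhibition and lower numbers for stronger inhibition. Compound 1 `CN(Cc1nc2cc(C(F)(F)F)ccc2nc1-c1ccccc1)c1ccc(F)cc1` gives 5000 nM in this assay. Compound 2 `CN(Cc1nc2cc(C(F)(F)F)ccc2nc1-c1ccccc1)c1ccc(OC(F)(F)F)cc1` gives 3000 nM in this assay. Compound 3 `COc1ccc(N(C)Cc2nc3cc(C(F)(F)F)ccc3nc2-c2ccccc2)cc1OC` gives 8000 nM in this assay. Compound 3 therefore carries the highest of the three numbers: its nearest neighbour is compound 1, with a 1.6-fold higher number from compound 1 to compound 3 (0.20 log units; within the scatter), and its furthest is compound 2, with a 2.7-fold higher number from compound 2 to compound 3 (0.43 log units; beyond the scatter), while the other pair is separated by a 1.7-fold lower number from compound 1 to compound 2 (0.22 log units; within the scatter).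

Compound 4 `Cc1ccc(N(C)Cc2nc3cc(C(F)(F)F)ccc3nc2-c2ccccc2)cc1` has not been measured. It differs from compound 3 by 4-methylphenyl in place of 3,4-dimethoxyphenyl on an amine nitrogen. Going by the values given here, the steps that bear on this are the two earlier exchanges of the aryl group on the same amine nitrogen, a 1.6-fold higher number from compound 1 to compound 3 (0.20 log units; within the scatter) and a 2.7-fold higher number from compound 2 to compound 3 (0.43 log units; beyond the scatter), one within the scatter and one modestly beyond it. Compound 4 returns to a single small substituent on that aryl group, as in compound 1 and compound 2, so a number near theirs is anticipated. Among the compounds with values here, because a 2.7-fold higher number from compound 2 to compound 3 (0.43 log units; beyond the scatter) was the only step beyond the scatter, any movement is expected to be small. For compound 4 the expected step is a 1.8-fold lower number from compound 3 to compound 4 (0.25 log units; within the scatter) in this assay. Compound 4 is thus estimated at 4500 nM in this assay, with a range from 2000 nM to 10000 nM.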

Compound 4, inhibition constant: 11000 nM
For compound 4 the middle estimate is 2.4-fold (0.39 log units) below the measured one; measured number above the stated range.
By their numbers in this assay, from the lowest: compounds 2, 1, 3 and 4 (each within the scatter of the next, the first and the last beyond it).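

In this assay, the 4-methylphenyl group on the amine nitrogen cannot be told apart from the 3,4-dimethoxyphenyl group, with a 1.4-fold higher number from compound 3 to compound 4 (0.14 log units; within the scatter), so returning to a single substituent on this aryl group did not by itself restore numbers like those of compound 1 and compound 2. The identity of that single substituent does matter here: methyl in place of fluoro on the aromatic carbon gives a 2.2-fold higher number from compound 1 to compound 4 (0.34 log units; beyond the scatter), and methyl in place of trifluoromethoxy gives a 3.7-fold higher number from compound 2 to compound 4 (0.56 log units; beyond the scatter), both modest but beyond the scatter, whereas the earlier fluoro and trifluoromethoxy pair had stayed within it. Nothing in the available data accounts for these differences.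

On these data alone, whether a hydroxyl, an amine or a carboxylic acid on that aromatic carbon would give a number lower than that of compound 2 remains open. Also open, as far as these compounds go, is whether the gaps seen with the methyl group would persist if the methyl on the amine nitrogen gave way to a hydrogen or a longer chain.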